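From Propyl to Fluoro at the Assay Limit

A few compounds are considered here, and "the series" means these few. Any claim that something is new, unique, unknown or untested is made for them only; others in the source may bear on it.

Among the measured compounds shown here, in a functional assay on the whole organism with Mus musculus as the target (on this read-out higher numbers stand for an effect only at larger amounts of compound and lower numbers for an effect already at smaller amounts), compound 1 `Cc1c(C)c2c(c(C)c1N)CC(C)(CNc1ccccc1)O2` gives 15.7 mg/kg and so far provides the only exact number. Compound 2 `CCCc1ccc(C2c3c(C)c(N)c(C)c(C)c3OC2(C)C)cc1` reaches only a limit in this assay at > 50 mg/kg and so has no exact place on the scale. Compound 3 `Cc1c(C)c2c(c(C)c1N)C(c1ccc(F)cc1)C(C)(C)O2` departs from compound 2 in one place fluoro in place of propyl on an aromatic carbon with fluoro in place of propyl on an aromatic carbon. For the measured compounds named here, no measured pair shows what such a change does, and compound 1 differs from compound 2 in more than that one place. A modest shift toward smaller doses is expected in this assay for the step of an at least 1.6-fold lower number from compound 2 to compound 3 (0.22 log units; that floor lies within the scatter) and it may stay within the usual scatter. Compound 3 is estimated at 30 mg/kg with values between 10 mg/kg and 80 mg/kg as the expected range.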

Compound 3, dose for 50% inhibition: 26.7 mg/kg
Compound 3: the middle estimate sits 1.1-fold (0.05 log units) above what was measured; measured number inside the range.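

On this aromatic carbon, para to a large group, fluoro in place of propyl brings the compound onto the measured scale of this assay: compound 3 has an exact number, 26.7 mg/kg. The change reads as an at least 1.8-fold lower number from compound 2 to compound 3 (0.27 log units; that floor lies within the scatter), so only a floor for its size is known, and the true step may be larger. That floor rests on a limit, not a number, for compound 2: the limit of > 50 mg/kg in this assay, at which 1 of the 3 values shown sits.

Open, from the compounds shown here alone, is what a hydrogen, a chloro or a methoxy at this place would give in this assay, and so whether fluoro itself matters or only the loss of propyl. Also open, going by these compounds, is how a chain of intermediate length such as ethyl, or an amine, would read here.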